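Acetyl to (1-bromoethyl)carbonyl on the shared core

This account rests on a few compounds, and the source may have more. Where it says the series, first, only, none or still open, it means among the compounds named here.

Two compounds of this series have numbers in a functional assay on KYSE-450 cells (Homo sapiens) for inhibition, read by MTT assay, with a stated time of 48 h; a lower number here means a stronger inhibitor, a higher number a weaker inhibitor. Compound 1 `COc1ccc(CN(C(C)=O)c2cc(OC)c(OC)c(OC)c2)cc1O` gives 160 nM and stands at the lowest of the two numbers. Compound 2 `C/C=C/C(=O)N(Cc1ccc(OC)c(Cl)c1)c1cc(OC)c(OC)c(OC)c1` gives 10100 nM in this assay, a gap beyond the scatter, but compound 2 differs from compound 1 in more than one place, so its number tells nothing about any single change.

Compound 3 `COc1ccc(CN(C(=O)C(C)Br)c2cc(OC)c(OC)c(OC)c2)cc1O` is not yet measured in this assay. It differs from compound 1 in one place: 1-bromoethyl in place of methyl on a carbonyl carbon. Going by the values given here, no measured pair shows what this change does here; the only other number, that of compound 2, carries a different acyl group together with other changes and does not separate them.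

With nothing measured for this exact change, the expectation for compound 3 rests on compound 1 alone: a step of a 2.5-fold higher number from compound 1 to compound 3 (0.40 log units; beyond the scatter) towards a somewhat higher number is expected, of a size that may or may not exceed the scatter. Compound 3 is estimated at 400 nM, within 100 nM to 2000 nM.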

Compound 3, half-maximal inhibitory concentration: 160 nM
Compound 3: middle estimate off by 2.5-fold (0.40 log units), on the high side; measured number inside the range.
By their numbers in this assay, from the lowest: compounds 1 and 3 (each within the scatter of the next); then compound 2.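

The acyl position on the shared core now has its first reading for a single change: in this assay, 1-bromoethyl in place of methyl on a carbonyl carbon gives no change at the digits printed from compound 1 to compound 3 (within the scatter). With 3 heavy atoms entering and 1 leaving, this position accepts a larger group carrying bromine with no loss in this assay, something compound 2 at 10100 nM could not show, as it carries a different acyl group together with other changes. Nothing available explains why the number holds across this change.

Still open, going by these compounds, is how far this acceptance reaches: a longer chain such as n-butyl, an amine or a carboxylic acid on the same carbonyl carbon could each give a different answer. Also open, on these data alone, is the part played by the bromine itself, which a plain ethyl group in the same place would separate from the added carbon.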